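The compounds below may be only part of what the source reports. "The series", "measured", "known", "first", "only" and "open" are said of these compounds alone.

Three compounds have been measured in a functional assay on PC-3 cells (Homo sapiens) for cytotoxicity, read by MTT assay, with a stated time of 72 h; on this read-out higher numbers stand for weaker inhibition and lower numbers for stronger inhibition:

Compound 1, `O=S(=O)(c1ccccc1)c1nc2ccccc2nc1Nc1ccc(C(F)(F)F)cc1`, gives 3550 nM.
Compound 2, `COc1ccc(S(=O)(=O)c2nc3ccccc3nc2Nc2ccc(C(F)(F)F)cc2)cc1`, gives 330 nM.
Compound 3, `COc1cc(Nc2nc3ccccc3nc2S(=O)(=O)c2ccc(Br)cc2)cc(OC)c1`, gives 18200 nM.

Compound 1 and compound 2 share one core and differ in a single place: methoxy in place of hydrogen on an aromatic carbon. That one change produced an 11-fold lower number from compound 1 to compound 2 (1.03 log units; beyond the scatter), a clear move toward stronger inhibition.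

Compound 3 is built differently around the shared quinoxaline-sulfone arrangement; how its core differs from the core of compound 1 is not broken down here. What the values show is that compound 3 gives the highest number of the three, higher than compound 1 and far higher than compound 2, so it is the weakest inhibitor among the measured compounds.

Compound 4, `COc1cc(Nc2nc3ccccc3nc2S(=O)(=O)c2ccc(Br)cc2)cc(OC)c1OC`, has not yet been measured. It differs from compound 3 in one place: methoxy in place of hydrogen on an aromatic carbon. Among the measured compounds shown here, this is the same kind of change as the one from compound 1 to compound 2, but it is not the same change: in compound 4 the new methoxy sits ortho to two methoxy groups, which was not so for the earlier change, where the entering group was only para to a large group.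

For the measured compounds named here, the expectation for compound 4 rests on an 11-fold lower number from compound 1 to compound 2 (1.03 log units; beyond the scatter), the one measured example of this kind of change, tempered by the place not being the same. A smaller step is therefore expected, estimated as a 3.0-fold lower number from compound 3 to compound 4 (0.48 log units; beyond the scatter). For compound 4 the estimated value in this assay is 6000 nM, expected to lie between 1500 nM and 20000 nM.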

Compound 4, half-maximal inhibitory concentration: 19800 nM
The estimate for compound 4 lay 3.3-fold (0.52 log units) below the measured number, within the range that was stated.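

In this assay, the new step is a 1.1-fold higher number from compound 3 to compound 4 (0.04 log units; within the scatter), so on this core the added methoxy brought no measurable difference. Methoxy in place of hydrogen on an aromatic carbon therefore did not give the same result on the two cores: the same change on two cores in this assay, an 11-fold lower number (1.03 log units; beyond the scatter) from compound 1 to compound 2 and a 1.1-fold higher number (0.04 log units; within the scatter) from compound 3 to compound 4, 12-fold (1.07 log units) apart, beyond the scatter of two such steps

This shows that the clear move toward stronger inhibition seen with compound 2 cannot simply be assumed when the same kind of change is made on another core in this series, but it does not show what sets the two results apart. The two pairs differ both in the rest of the structure and in where the new methoxy sits, and these data cannot separate those two differences, nor can two pairs establish a rule.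

From the compounds shown here alone, it remains open whether a methoxy would have a larger effect on compound 3 if it replaced the bromine on the ring attached to the sulfone, which is the ring that carries the methoxy in compound 2. Going by these compounds, it is also open whether a different group at the place changed in compound 4, such as an amine, a hydroxyl or a longer ether chain, would move the number away from that of compound 3.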